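Swapping tert-butoxycarbonyl for a chloropyridinylmethyl group

The source may report more compounds than this note shows. Statements on the series, on what has been measured and on what is new or still open speak of the compounds shown alone.

Compound 3 `Cc1ccc2c(NCc3ccc(NC(=O)C4CCN(C(=O)OC(C)(C)C)CC4)cc3)nc(N(C)C)nc2c1` carries a tert-butoxycarbonyl group on the ring nitrogen. In a functional assay on SV5A8 cells (Homo sapiens) for cytotoxicity (on this read-out lower numbers stand for stronger inhibition and higher numbers for weaker inhibition), compound 3 gives > 4820 nM, which is a limit of the assay rather than a number. Compound 1 `Cc1ccc2c(NCc3ccc(NC(=O)C4CCN(Cc5ccc(F)cc5)CC4)cc3)nc(N(C)C)nc2c1` gives > 4820 nM, also a limit. Compound 2 `Cc1ccc2c(NCc3ccc(NC(=O)C4CCN(Cc5ccc(Cl)cc5)CC4)cc3)nc(N(C)C)nc2c1` gives > 3180 nM, again a limit. The change leading to compound 4 `Cc1ccc2c(NCc3ccc(NC(=O)C4CCN(Cc5cc(Cl)ccn5)CC4)cc3)nc(N(C)C)nc2c1` is (4-chloropyridin-2-yl)methyl in place of tert-butoxycarbonyl on an amine nitrogen in a ring. The measured steps that bear on it, a step that the two limits leave unreadable from compound 1 to compound 3 and a step that the two limits leave unreadable from compound 2 to compound 3, cannot be read in size; the limit of > 3180 nM in this assay, at which 1 of the 3 values shown sits, and the limit of > 4820 nM in this assay, at which 2 of the 3 values shown sit, show where all the values sit. Compound 4 is therefore expected to stay near the same weak level, with the step that the limit leaves unreadable from compound 3 to compound 4 expected to be no more than the usual scatter. The estimate for compound 4 is 6000 nM, between 2000 nM and 20000 nM.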

Compound 4, half-maximal inhibitory concentration: > 5400 nM
Compound 4 ended at the assay's limit (the forecaster's own chance of this, stated with the estimate: 80%); the middle value is on the limit's open side.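

Compound 4 gives only a limit of the assay, as do compound 1, compound 2 and compound 3, and the steps among them cannot be read. Going by these compounds, whether any of these changes alters the read-out at all remains open.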